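Phenethyl in Place of Furan on a Shared Core

This account rests on a few compounds, and the source may have more. Where it says the series, first, only, none or still open, it means among the compounds named here.

Among the measured compounds shown here, compound 3 `O=C(Nn1c(-c2cccc([N+](=O)[O-])c2)nc2c(-c3ccco3)n[nH]c2c1=O)c1ccccc1` gives 23% in a functional assay on SK-MEL-2 cells (Homo sapiens) for cytotoxicity, read by sulforhodamine B assay, with a stated time of 2 days, tested at 100 uM (on this read-out higher numbers stand for more inhibition at the one concentration tested (going by the name of the read-out) and lower numbers for less inhibition), the lowest of the three numbers measured so far. Compound 1 `O=C(Nn1c(-c2cccc([N+](=O)[O-])c2)nc2c(-c3ccc(Cl)cc3)n[nH]c2c1=O)c1ccccc1` gives 89% and compound 2 `O=C(Nn1c(-c2cccc([N+](=O)[O-])c2)nc2c(-c3ccc(F)cc3)n[nH]c2c1=O)c1ccccc1` gives 88.5%, so compound 3 lies far beneath both, as the steps of a number 66 percentage points lower from compound 1 to compound 3 (beyond the scatter) and a number 65.5 percentage points lower from compound 2 to compound 3 (beyond the scatter) show. Compound 4 `O=C(Nn1c(-c2cccc([N+](=O)[O-])c2)nc2c(CCc3ccccc3)n[nH]c2c1=O)c1ccccc1` differs from compound 3 by phenethyl in place of furan-2-yl on an aromatic carbon, placed on an aromatic carbon of a five-membered aromatic ring with 2 nitrogen, part of a fused or bridged system of two rings. Both large steps bear on this change: a six-membered aromatic ring of carbon only at this place went with high inhibition, furan-2-yl with low. Phenethyl carries such a ring, though within a larger group no measured compound has, so a recovery of uncertain size is expected. Compound 4 is therefore estimated at 55%, ranging from 20% to 90%. This estimate means an expected upward step a number 32 percentage points higher from compound 3 to compound 4 (beyond the scatter).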

Compound 4, a percentage reported as inhibition, at one concentration (the size of the read-out at that concentration, not a potency): 92%
The estimate for compound 4 lay 37 percentage points below the measured number, outside the stated range (above it).
By their numbers in this assay, from the lowest: compound 3; then compounds 2, 1 and 4 (each within the scatter of the next).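

In this assay, phenethyl at this place gives a large rise over furan-2-yl, a number 69 percentage points higher from compound 3 to compound 4 (beyond the scatter), so a six-membered aromatic ring of carbon only can sit within this larger group as well as stand as 4-chlorophenyl or 4-fluorophenyl. The change from those two groups shows no difference that can be told: a number 3.5 percentage points higher from compound 2 to compound 4 (within the scatter) and a number 3 percentage points higher from compound 1 to compound 4 (within the scatter). Nothing measured here accounts for the low number of the furan-2-yl compound.

Open, on these data alone, is whether a butyl chain or an amine at this place would keep the number high. Benzyl, which is shorter than phenethyl, leaves the same question open.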